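A few compounds are considered here, and "the series" means these few. Any claim that something is new, unique, unknown or untested is made for them only; others in the source may bear on it.

In an ADME assay on HOS cells (Homo sapiens) for cytotoxicity, read by luminescence and ATP content, with a stated time of 48 h (on this read-out lower numbers stand for higher toxicity in this test and higher numbers for lower toxicity in this test), compound 1 `COc1ccc2c(O)c(C(=O)NCc3ccc(F)cc3F)c(=O)n(O)c2n1` gives 12000 nM and compound 2 `Nc1c(C(=O)NCc2ccc(F)cc2F)c(=O)n(O)c2ncc(CCCCc3ccccc3)cc12` gives 13000 nM as its value, so the two stand level within the scatter. Compound 3 `Nc1c(C(=O)NCc2ccc(F)cc2F)c(=O)n(O)c2ncc(CCC(=O)O)cc12` carries carboxy in place of phenethyl on a saturated chain carbon, two bonds along the chain from an aromatic carbon and has not yet been measured. No measured step among these compounds speaks to this change, so the expectation is loose. A move to a higher number is expected, an estimated 3.8-fold higher number from compound 2 to compound 3 (0.59 log units; beyond the scatter) in this assay as the likely size. For compound 3 the estimate is 50000 nM with 14000 nM to 200000 nM as its expected range.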

Compound 3, half-maximal cytotoxic concentration: > 250000 nM
Compound 3: a limit, no number; the forecaster's own chance of this, stated with the estimate: 30%; middle value at least 5.0-fold (0.69 log units) from the limit.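

Carboxy in place of phenethyl on a saturated chain carbon, two bonds along the chain from an aromatic carbon, gives an at least 19-fold higher number from compound 2 to compound 3 (1.28 log units; beyond the scatter) in this assay. As far as these compounds go, compound 3 gives > 250000 nM, which is a limit of the assay and not a number, so the full size of the step stays unknown. Going by these compounds alone, this is the first step at this position, and it shows that the read-out answers to the group carried there. Whether the entering carboxylic acid or the leaving aromatic ring accounts for the step stays open. An amine, a methyl ester or a plain alkyl chain at the same place would help separate the two.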